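The source may hold more compounds than are shown below. What is called first, only, known or untested is meant among the compounds shown, and "the series" means these compounds.

Measured in a functional assay on the whole organism for inhibition, with Rattus norvegicus as the target; on this read-out higher numbers stand for an effect only at larger amounts of compound and lower numbers for an effect already at smaller amounts:

- compound 1 `CC(C)c1ccc(OC(Cc2ccccc2)C(=O)O)cc1`: 50 mg/kg
- compound 2 `Cc1ccc(CC(Oc2ccc(C(C)C)cc2)C(=O)O)cc1`: < 50 mg/kg (a limit of the assay)
- compound 3 `CC(C)c1ccc(OC(C)(Cc2cccc(C(F)(F)F)c2)C(=O)O)cc1`: 5 mg/kg

Among the measured compounds shown here, only two of these values are actual numbers. Compound 3 has the lower of them at 5 mg/kg, while compound 1 stands at 50 mg/kg, a gap beyond the usual scatter. Compound 2 gives < 50 mg/kg, which is a limit and not a number.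

The next compound is compound 4 `CCCc1cccc(CC(C)(Oc2ccc(C(C)C)cc2)C(=O)O)c1`. Its difference from compound 3 is propyl in place of trifluoromethyl on an aromatic carbon.

For the measured compounds named here, no measured pair makes this exact exchange. The nearest evidence is a number no higher from compound 1 to compound 2 (the limit leaves the size open), where methyl replaces hydrogen on an aromatic carbon. Its size cannot be read, but it shows compound 2 with no higher number after that addition. This is thin support, and it gives no reason to expect a large rise or fall in this assay.

The expected change is therefore small, with no step beyond the scatter anticipated. The estimated step is a 1.6-fold higher number from compound 3 to compound 4 (0.20 log units; within the scatter). For compound 4 the estimate is 8 mg/kg, with an expected range from 2.5 mg/kg to 25 mg/kg.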

Compound 4, dose for half-maximal effect: 1 mg/kg
Beside the measured number, compound 4's estimate is 8.0-fold (0.90 log units) above it, outside the stated range (below it).
By their numbers in this assay, from the lowest: compound 4; then compound 3; then compound 1.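

Exchanging trifluoromethyl for propyl on this aromatic carbon gives, in this assay, a 5.0-fold lower number from compound 3 to compound 4 (0.70 log units; beyond the scatter) and so shows that the group at this place can change the dose needed by more than the usual scatter. Neither group has a ring, a net charge, or a hydrogen-bond donor or acceptor, so a clear change arises here between two groups that have none of these features, although this single pair cannot say which difference between them matters. The earlier step, methyl in place of hydrogen on an aromatic carbon, could not show any such size, and it cannot be read because compound 2 carries a limit and not a number: the limit of < 50 mg/kg in this assay, at which 1 of the 4 values shown sits.

What the compounds shown leave open is whether a longer chain such as butyl, a shorter one such as ethyl, or an amine at this place would lower the number further or raise it. They also leave open whether propyl would bring a similar step on the core of compound 1, which differs from the core of compound 3.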